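Chloro on the phenyl of a thiazinone amide series

The source may report more compounds than this note shows. Statements on the series, on what has been measured and on what is new or still open speak of the compounds shown alone.

Measured compounds:
- compound 1 `Cc1sc2nc(NC(=O)CCCc3ccccc3)sc(=O)c2c1C`: "not determined" (no result reported)
- compound 2 `O=C(CCCc1ccccc1)Nc1nc2ccc(Cl)cc2c(=O)s1`: "not determined" (no result reported)
- compound 3 `O=C(CCCc1ccccc1)Nc1nc2ccccc2c(=O)s1`: 2500 nM

Three compounds of the series carry the same amide chain ending in a phenyl ring. In an assay on CHO cells for displacement of a labelled ligand from adenosine receptor A1 (Homo sapiens), read by scintillation counting, with a stated time of 90 min (on this read-out higher numbers stand for weaker inhibition and lower numbers for stronger inhibition), compound 3 gives 2500 nM. In this assay, among the measured compounds shown here, compound 1 gives "not determined" (no result reported) and compound 2 gives "not determined" (no result reported), so compound 3 holds the only number in the set and no comparison within the measured compounds is possible.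

Compound 4 `O=C(CCCc1cccc(Cl)c1)Nc1nc2ccccc2c(=O)s1` is the next member and is yet to be measured in this assay. It differs from compound 3 by chloro in place of hydrogen on an aromatic carbon, meta to a large group, so that the phenyl becomes 3-chlorophenyl. The change adds one heavy atom and no ring, donor, acceptor or charge.

For the measured compounds named here, no step between two measured compounds exists to calibrate this change. A single chloro on the terminal ring is expected to move the inhibition constant little, if at all, and any shift is expected to sit within the usual scatter of this assay; the expected step is a 1.4-fold lower number from compound 3 to compound 4 (0.14 log units; within the scatter). Compound 4 is therefore estimated at 1800 nM, with a range from 600 nM to 6000 nM.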

Compound 4, inhibition constant: > 10000 nM
Compound 4: only a limit was reported; the forecaster's own chance of this, stated with the estimate: 10%; at least 5.5-fold (0.74 log units) between middle value and limit.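

Substitution on the terminal ring of the amide chain matters in this series: the change of phenyl to 3-chlorophenyl gives an at least 4.0-fold higher number from compound 3 to compound 4 (0.60 log units; beyond the scatter). Among the compounds shown here, this is the first step that can be read here, as the steps involving compound 1 and compound 2 cannot be read. In this assay compound 4 gives > 10000 nM, which is a limit of the assay and not a number: the limit of > 10000 nM in this assay, at which 1 of the 4 values shown sits. On this single pair, then, the aromatic carbon meta to a large group does not accept chloro in place of hydrogen without a loss of inhibition, although the change adds only one heavy atom, and the pair does not show which property of chloro lies behind the step.

From the compounds shown here alone, whether the loss is specific to chloro remains open, as a fluoro or a methoxy on the same carbon would be needed to separate the effect of this group from that of any substituent at this place. Also open, going by these compounds, is whether the same change would act alike on the core of compound 1 or of compound 2, or with a shorter chain leading to the ring.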